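Swapping a Fluorinated Ring for a Sulfur Group

A few compounds are considered here, and "the series" means these few. Any claim that something is new, unique, unknown or untested is made for them only; others in the source may bear on it.

Compound 1 `CS(=O)(=O)Nc1ccc(CNC(=O)c2ccc(C3(C(F)(F)F)CC3)cc2)c(Cl)c1` gives the higher of the two numbers measured in an ADME assay on microsomes from liver (Rattus norvegicus, strain Sprague-Dawley) for metabolic stability, read by HPLC, using NADPH, with stated times of 5 min and 60 min, tested at 10 uM (a lower number here means slower removal, a higher number faster removal of the compound), where compound 1 gives 7.5 mL.min-1.g-1. Compound 2 `CC(C)(O)c1ccc(C(=O)NCc2ccc(NS(C)(=O)=O)cc2Cl)cc1` gives 1.5 mL.min-1.g-1, and the step of a 5.0-fold lower number from compound 1 to compound 2 (0.70 log units; beyond the scatter) shows that a change at this aromatic carbon can move the number well beyond the scatter. Compound 3 `CS(=O)(=O)Nc1ccc(CNC(=O)c2ccc(S(F)(F)(F)(F)F)cc2)c(Cl)c1` carries a different change at the same place: a group of 6 heavy atoms (5 fluorine, 1 sulfur; no ring) in place of a group of 7 heavy atoms (4 carbon, 3 fluorine; one three-membered non-aromatic ring of carbon only), on an aromatic carbon. Within the data shown here, only the step from compound 1 to compound 2 bears on it, and the entering group was not measured there, so a smaller shift toward slower removal is expected: a 1.7-fold lower number from compound 1 to compound 3 (0.22 log units; within the scatter). Compound 3 is therefore estimated at 4.5 mL.min-1.g-1, within 1.5 mL.min-1.g-1 to 12 mL.min-1.g-1.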

Compound 3, intrinsic clearance in microsomes: 9.8 mL.min-1.g-1
Compound 3: the middle estimate sits 2.2-fold (0.34 log units) below what was measured, and the stated range covers the measured number.
By their numbers in this assay, from the lowest: compound 2; then compounds 1 and 3 (each within the scatter of the next).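

In this assay, exchanging 1-(trifluoromethyl)cyclopropyl for the group of 5 fluorine and 1 sulfur gives no readable change, with a 1.3-fold higher number from compound 1 to compound 3 (0.12 log units; within the scatter), so the two groups cannot be told apart here. The hydroxy-bearing group remains the one that differs, with a 6.5-fold higher number from compound 2 to compound 3 (0.82 log units; beyond the scatter), which sets the sulfur-bearing group apart from 1-hydroxy-1-methylethyl. Nothing available explains these numbers. Going by these compounds, whether an amine, a carboxylic acid or a plain tert-butyl at this aromatic carbon would give a number like that of compound 2 or like that of compound 1 remains open.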